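A few compounds are considered here, and "the series" means these few. Any claim that something is new, unique, unknown or untested is made for them only; others in the source may bear on it.

In a functional assay on MCF7 cells (Homo sapiens) for antiproliferative activity, read by MTT assay, with a stated time of 48 h (on this read-out higher numbers stand for weaker inhibition and lower numbers for stronger inhibition), three compounds have been measured:

Compound 1 `Cc1ccccc1-n1nncc1CN1C(=O)C2(C(C#N)=C(N)Oc3c(N)cc4nc5ccccc5nc4c32)c2ccccc21` gives > 50000 nM, a limit of the assay.
Compound 2 `N#CC1=C(N)Oc2c(N)cc3nc4ccccc4nc3c2C12C(=O)N(Cc1cnnn1-c1ccccc1Cl)c1ccccc12` gives 34400 nM.
Compound 3 `N#CC1=C(N)Oc2c(N)cc3nc4ccccc4nc3c2C12C(=O)N(Cc1cnnn1-c1ccc([N+](=O)[O-])cc1)c1ccccc12` gives > 50000 nM, a limit of the assay.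

Compound 3 therefore stands at the limit of > 50000 nM in this assay, at which 2 of the 3 values shown sit, and only compound 2 returns a number. The step from the chlorophenyl compound to the nitrophenyl compound is recorded as an at least 1.4-fold higher number from compound 2 to compound 3 (0.16 log units; that floor lies within the scatter), while a step that the two limits leave unreadable from compound 1 to compound 3 cannot be sized at all, since both ends are limits.

Compound 4 `N#CC1=C(N)Oc2c(N)cc3nc4ccccc4nc3c2C12C(=O)N(Cc1cnnn1-c1ccc([N+](=O)[O-])cc1[N+](=O)[O-])c1ccccc12` differs from compound 3 by nitro in place of hydrogen on an aromatic carbon. For the measured compounds named here, the only readable step that bears on it is the small one from compound 2 to compound 3, and it does not reach beyond the scatter; nothing in the set shows a nitro substitution pulling the number down. Compound 3 already stands at the limit, so compound 4 is expected to sit at or beyond that limit as well, with an expected step that the limit leaves unreadable from compound 3 to compound 4. The estimate for compound 4 in this assay is 70000 nM, expected to lie between 25000 nM and 200000 nM.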

Compound 4, half-maximal inhibitory concentration: 20900 nM
Estimate against measurement, compound 4: 3.3-fold (0.52 log units) above; measured number outside the range, below it.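

In this assay, for the compounds shown here, nitro in place of hydrogen on an aromatic carbon, ortho to a large group and meta to a nitro group, gives an at least 2.3-fold lower number from compound 3 to compound 4 (0.37 log units; beyond the scatter), the first step in this set that lies beyond the scatter, so a 4-nitrophenyl group does not hold every compound of this series at the limit. Set against the other two groups at this nitrogen, 2,4-dinitrophenyl gives an at least 2.3-fold lower number from compound 1 to compound 4 (0.37 log units; beyond the scatter) with 2-methylphenyl, but only a 1.6-fold lower number from compound 2 to compound 4 (0.22 log units; within the scatter) with 2-chlorophenyl, so compound 4 and compound 2 are not separated. Compound 1 and compound 3 remain limits and not numbers: the limit of > 50000 nM in this assay, at which 2 of the 4 values shown sit.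

The compounds shown leave open whether the step needs the 4-nitro group at all, which a 2-nitrophenyl compound would test. They also leave open whether an amine or a methoxy group on that same carbon would give a similar step.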